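This account rests on a few compounds, and the source may have more. Where it says the series, first, only, none or still open, it means among the compounds named here.

Compound 1 `O=C(N[C@H]1CN(S(=O)(=O)c2ccccc2)C[C@@H]1C(=O)N[C@H]1CCCNC1)c1cc(-c2ccccc2Cl)on1` gives 98% in a functional assay on HEK293 cells for agonist activity at growth hormone secretagogue receptor type 1 (Homo sapiens), read by HTRF and inositol phosphate accumulation, with a stated time of 90 min, in the presence of a further agent that is not named here; a higher number here means a larger maximal response, a lower number a smaller maximal response.
Compound 2 `O=C(N[C@H]1CN(S(=O)(=O)c2ccccc2)C[C@@H]1C(=O)N1C[C@H]2CCNC[C@H]21)c1cc(-c2ccccc2Cl)on1` gives 98% in this assay.

In this assay compound 2 stands level with compound 1 within the scatter. Compound 3 `O=C(N[C@H]1CN(S(=O)(=O)c2ccccc2)C[C@@H]1C(=O)NC[C@@H]1CCCN1)c1cc(-c2ccccc2Cl)on1` differs from compound 2 in one place: a group of 7 heavy atoms (5 carbon, 2 nitrogen; one five-membered non-aromatic ring with 1 hetero atom) in place of a group of 8 heavy atoms (6 carbon, 2 nitrogen; one four-membered non-aromatic ring with 1 hetero atom, one six-membered non-aromatic ring with 1 hetero atom), on a carbonyl carbon. For the measured compounds named here, the one measured step that bears on this change is no change at the digits printed from compound 1 to compound 2 (within the scatter), a swap of the group on the same carbonyl carbon that left the maximal response unchanged. On that basis no step beyond the scatter is expected for compound 3 in this assay; the expected step is a number 2 percentage points lower from compound 2 to compound 3 (within the scatter). Compound 3 is therefore estimated at 96%, with a range from 82% to 105%.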

Compound 3, largest response reached (Emax), in percent of the reference or control that the assay uses: 102%
Compound 3: middle estimate off by 6 percentage points, on the low side, within the range that was stated.
By their numbers in this assay, from the lowest: compounds 1, 2 and 3 (each within the scatter of the next).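

In this assay, ((pyrrolidin-2-yl)methyl)amino on this carbonyl carbon gives a number 4 percentage points higher from compound 2 to compound 3 (within the scatter) and a number 4 percentage points higher from compound 1 to compound 3 (within the scatter). Three differently shaped ring-bearing groups at this place, including a five-membered ring in place of the six-membered ring of compound 1, thus give maximal responses within the scatter of one another. No measurement at hand accounts for this result. Still open, going by these compounds, is whether the second nitrogen matters, as a cyclohexylamino group on the same carbonyl carbon would show. Also open, on these data alone, is how these groups compare in potency, since only maximal response is given here.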